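One Added Methoxy: From Compound 2 to Compound 3

This account rests on a few compounds, and the source may have more. Where it says the series, first, only, none or still open, it means among the compounds named here.

Compound 1 `COc1cc(NC(=O)/C=C/c2cccc(OCc3ccccc3)c2)cc(OC)c1OC`: 2400 nM
Compound 2 `C=C(Br)C(=O)Nc1cccc(/C=C/C(=O)Nc2ccc(OC)c(OC)c2)c1`: 2800 nM

Both compounds were tested in a functional assay on MCF7 cells (Homo sapiens) for inhibition, read by MTT assay, with a stated time of 72 h; on this read-out higher numbers stand for weaker inhibition and lower numbers for stronger inhibition. There, compound 2 at 2800 nM stands level, within the scatter, with compound 1 at 2400 nM. The next compound, compound 3 `C=C(Br)C(=O)Nc1cccc(/C=C/C(=O)Nc2cc(OC)c(OC)c(OC)c2)c1`, departs from compound 2 in one place: methoxy in place of hydrogen on an aromatic carbon. In short, methoxy stands in place of hydrogen on an aromatic carbon. Going by the values given here, no measured pair of compounds shows what this change does, so any forecast rests on thin evidence. A modest move toward stronger inhibition in this assay is expected, and the estimated size is a 1.9-fold lower number from compound 2 to compound 3 (0.27 log units; within the scatter). A result within the scatter of compound 2 would not be surprising. For compound 3 the estimated value is 1500 nM, with an expected range from 400 nM to 5000 nM.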

Compound 3, half-maximal inhibitory concentration: 1800 nM
For compound 3 the middle estimate is 1.2-fold (0.08 log units) below the measured one; the range from low to high includes it.
By their numbers in this assay, from the lowest: compounds 3, 1 and 2 (each within the scatter of the next).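

In this assay, the first direct test of this change, methoxy on the aromatic carbon ortho to one methoxy group and meta to another gives a step that stays within the scatter (a 1.6-fold lower number from compound 2 to compound 3 (0.19 log units; within the scatter)). The exchange of benzyloxy for ((1-bromoethenyl)carbonyl)amino on an aromatic carbon also stays within it (a 1.3-fold lower number from compound 1 to compound 3 (0.12 log units; within the scatter)), so neither change clearly separates these compounds. Nothing shown here offers an explanation for these values.

The compounds shown leave open whether an amine or a carboxylic acid on this aromatic carbon would give a step beyond the scatter. Going by these compounds alone, with only one step for this methoxy change, they also leave open whether the same change would give a similar step in a different compound.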